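The source may hold more compounds than are shown below. What is called first, only, known or untested is meant among the compounds shown, and "the series" means these compounds.

Measured compounds in an assay on cells for inhibition of S-adenosylmethionine decarboxylase proenzyme (Homo sapiens), read by mass spectrometry, at pH 7.2; on this read-out higher numbers stand for weaker inhibition and lower numbers for stronger inhibition:
compound 1 `Nc1cccc(Nc2cc(Cl)cc(Cl)c2)n1`: > 180000 nM, a limit of the assay.
compound 2 `Cc1cc(Nc2cccc(Br)c2)nc(N)n1`: > 180000 nM, a limit of the assay.
compound 3 `Cc1cc(Nc2cc(Cl)c(Cl)c(Cl)c2)nc(N)n1`: > 63000 nM, a limit of the assay.

Within the data shown here, compound 3 stands among three compounds for which this assay reports only limits and no number (the limit of > 180000 nM in this assay, at which 2 of the 3 values shown sit, (the limit of > 63000 nM in this assay, at which 1 of the 3 values shown sits)), so no measured step between compounds can be read from these data. Compound 4 `Cc1cc(Nc2cc(Cl)c(Oc3ccccc3)c(Cl)c2)nc(N)n1` differs from compound 3 by phenoxy in place of chloro on an aromatic carbon. Among the measured compounds shown here, with no measured step to rest on, no shift beyond the scatter in this assay is expected in either direction. Compound 4 is expected at 100000 nM, range 20000 nM to 300000 nM. The expected step is a step that the limit leaves unreadable from compound 3 to compound 4, an estimate resting on a limit rather than a number.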

Compound 4, half-maximal inhibitory concentration: > 180000 nM
Compound 4: only a limit was reported; the forecaster's own chance of this, stated with the estimate: 70%; middle value at least 1.8-fold (0.25 log units) away from the limit.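

Compound 3 and compound 4 are both reported only as limits in this assay, so the step between them cannot be read. The compounds shown leave open whether any member of this series gives a measurable inhibition in this assay.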